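From nitro to amino at the assay limit

This account rests on a few compounds, and the source may have more. Where it says the series, first, only, none or still open, it means among the compounds named here.

Compound 1 `COc1cc(OC)n2cc(-c3ccc(N)cc3)nc2n1` gives > 100000 nM
Compound 2 `Cc1ccc2nc(-c3ccc([N+](=O)[O-])cc3)cn2c1` gives > 100000 nM

In a functional assay on A549 cells (Homo sapiens) for antiproliferative activity, read by MTT assay, with a stated time of 72 h (on this read-out lower numbers stand for stronger inhibition of growth and higher numbers for weaker inhibition of growth), compound 2 stands at > 100000 nM as a limit and not a number. Compound 1 likewise gives only a limit (> 100000 nM). Both measured compounds therefore sit at the same limit (the limit of > 100000 nM in this assay, at which 2 of the 2 values shown sit). Compound 3 `Cc1ccc2nc(-c3ccc(N)cc3)cn2c1` has amino in place of nitro on an aromatic carbon of compound 2 (amino in place of nitro on an aromatic carbon). Compound 1 already carries an amino group on its own core and gives > 100000 nM as a limit, so only a small change is expected. The step is expected to lean towards stronger inhibition, if it is visible at all (an at least 1.4-fold lower number from compound 2 to compound 3 (0.15 log units; that floor lies within the scatter)). The estimate for compound 3 is 70000 nM within an expected range of 15000 nM to 100000 nM.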

Compound 3, concentration for 50% growth inhibition: > 100000 nM
Compound 3 ended at the assay's limit (the forecaster's own chance of this, stated with the estimate: 60%); middle value at least 1.4-fold (0.15 log units) from the limit.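

Going by these compounds alone, compound 2 and compound 3 both end at a limit and not at a number, so no step between them can be read: the limit of > 100000 nM in this assay, at which 3 of the 3 values shown sit. From the compounds shown here alone, how amino in place of nitro changes growth inhibition remains open.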